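Swapping Benzyl for 4-Iodophenyl on the Amine Nitrogen

The source may report more compounds than this note shows. Statements on the series, on what has been measured and on what is new or still open speak of the compounds shown alone.

Three compounds have been measured in a functional assay on MGC-803 cells (Homo sapiens) for inhibition, read by sulforhodamine B assay; on this read-out lower numbers stand for stronger inhibition and higher numbers for weaker inhibition:

compound 1, `COc1cccc(NC2=CC(=O)c3c(nc4n3[C@H]3OC[C@@H](O)[C@H]3OC4)C2=O)c1`: 1790 nM
compound 2, `CCOc1ccccc1NC1=CC(=O)c2c(nc3n2[C@H]2OC[C@@H](O)[C@H]2OC3)C1=O`: 2830 nM
compound 3, `O=C1C(NCc2ccccc2)=CC(=O)c2c1nc1n2[C@H]2OC[C@@H](O)[C@H]2OC1`: 3490 nM

The three share one core and differ only in the group attached to an amine nitrogen. Compound 3 has the highest of the three numbers, yet both steps that lead up to it, a 1.2-fold higher number from compound 2 to compound 3 (0.09 log units; within the scatter) and a 1.9-fold higher number from compound 1 to compound 3 (0.29 log units; within the scatter), fall inside the scatter, so the three cannot be told apart on these data.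

Compound 4, `O=C1C(Nc2ccc(I)cc2)=CC(=O)c2c1nc1n2[C@H]2OC[C@@H](O)[C@H]2OC1`, continues from compound 3 with a single change: 4-iodophenyl in place of benzyl on an amine nitrogen. Every step measured so far also exchanged the group on this amine nitrogen, and each stayed within the scatter, including a 1.6-fold higher number from compound 1 to compound 2 (0.20 log units; within the scatter). The two steps that moved an aromatic ring directly on the nitrogen to benzyl, a 1.9-fold higher number from compound 1 to compound 3 (0.29 log units; within the scatter) and a 1.2-fold higher number from compound 2 to compound 3 (0.09 log units; within the scatter), gave slightly higher numbers, so returning to a ring bonded directly to the nitrogen is expected to give, if anything, a slightly lower number. Among the compounds with values here, no measured compound carries iodine, so that part of the change has no precedent here.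

Compound 4 is therefore expected near 2200 nM, within 700 nM to 7000 nM, which means an expected step of a 1.6-fold lower number from compound 3 to compound 4 (0.20 log units; within the scatter).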

Compound 4, half-maximal inhibitory concentration: 2150 nM
Beside the measured number, compound 4's estimate is 1.0-fold (0.01 log units) above it, and the stated range covers the measured number.
By their numbers in this assay, from the lowest: compounds 1, 4, 2 and 3 (each within the scatter of the next).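

In this assay, the 4-iodophenyl group on the amine nitrogen gives a 1.6-fold lower number from compound 3 to compound 4 (0.21 log units; within the scatter) and a 1.3-fold lower number from compound 2 to compound 4 (0.12 log units; within the scatter) and a 1.2-fold higher number from compound 1 to compound 4 (0.08 log units; within the scatter) so it cannot be told apart from any of the three groups measured before it. The earlier compounds shown here showed this only for benzyl and for rings carrying an ethoxy or a methoxy group; compound 4 extends it to a ring carrying iodine, an atom that none of them has, and all four groups now fall within the scatter of one another. Nothing available here explains why this exchange leaves the number within the scatter.

Every group shown contains a six-membered carbon ring and has no net charge, so it remains open whether a ring carrying a carboxylic acid or an amine, or a plain alkyl chain with no ring at all, would move the number beyond the scatter. As far as these compounds go, the iodine's own contribution also remains open, since separating it from that of the ring would take a comparison between compound 4 and its counterpart with an unsubstituted phenyl group.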